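Sulfanyl in place of methylselanyl on the shared core

This account rests on a few compounds, and the source may have more. Where it says the series, first, only, none or still open, it means among the compounds named here.

Compound 1 `COc1ccc(CNc2nc([Se]C)nc3ccccc23)cc1` gives > 100000 nM in an ADME assay on BEAS-2B cells (Homo sapiens) for cytotoxicity, read by MTT assay, with a stated time of 72 h; a lower number here means a stronger inhibitor of growth, a higher number a weaker inhibitor of growth.
Compound 2 `CSc1ccc(CNc2nc([Se]C)nc3ccccc23)cc1` gives 35900 nM in this assay.

For compound 1 this assay reports only a limit, not a number (the limit of > 100000 nM in this assay, at which 1 of the 2 values shown sits). For the measured compounds named here, the single measured step, an at least 2.7-fold lower number from compound 1 to compound 2 (0.44 log units; beyond the scatter), concerns the methoxy and touches a different part of the molecule than the change considered here, so no measured step bears on it directly. Compound 3 `COc1ccc(CNc2nc(S)nc3ccccc23)cc1` differs from compound 1 by one sulfur atom in place of a group of 2 heavy atoms (1 carbon, 1 selenium; no ring), on an aromatic carbon. Compound 1 already sits at the limit, and no step beyond the scatter is expected in this assay for compound 3, whose value is estimated at 100000 nM, within 40000 nM to 300000 nM. The expected step is a number no higher from compound 1 to compound 3 (the limit leaves the size open).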

Compound 3, concentration for 50% growth inhibition: 6130 nM
Estimate against measurement, compound 3: 16-fold (1.21 log units) above; the whole stated range lies above it.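

On the aromatic carbon between two ring nitrogen atoms, sulfanyl in place of methylselanyl gives an at least 16-fold lower number from compound 1 to compound 3 (1.21 log units; beyond the scatter). This position is therefore not silent in this assay, and selenium is not needed for a measurable read-out: compound 3, which carries none, gives 6130 nM. Compound 1 stands at a limit, so the size of this step has only a floor: the limit of > 100000 nM in this assay, at which 1 of the 3 values shown sits.

Open, on these data alone, is whether the step comes from the exchange of selenium for sulfur or from the loss of the methyl, which a methylsulfanyl or an amine at this position would help separate. Also open, as far as these compounds go, is whether sulfanyl acts the same way alongside the methylsulfanyl of compound 2.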